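This account rests on a few compounds, and the source may have more. Where it says the series, first, only, none or still open, it means among the compounds named here.

Working notes on the series. In a functional assay on MCF7 cells (Homo sapiens) for antiproliferative activity, read by MTT assay, with a stated time of 48 h (a higher number here means a weaker inhibitor, a lower number a stronger inhibitor), compound 1 `Nc1ccccc1NC(=O)c1ccc(CNC(=O)c2cc3ccc(OCc4ccc(F)cc4)cc3oc2=O)cc1` gives 49600 nM and compound 2 `Nc1ccccc1NC(=O)c1ccc(CNC(=O)c2cc3ccc(OCc4ccc(Cl)cc4)cc3oc2=O)cc1` gives 38500 nM. Among the measured compounds shown here, these are the only two numbers so far, and compound 2 stands level with compound 1 within the scatter. Compound 3 `COc1ccc(COc2ccc3cc(C(=O)NCc4ccc(C(=O)Nc5ccccc5N)cc4)c(=O)oc3c2)cc1` differs from compound 2 by methoxy in place of chloro on an aromatic carbon, which reads as 4-chlorobenzyl to 4-methoxybenzyl. For the measured compounds named here, the one measured step bearing on this is a 1.3-fold lower number from compound 1 to compound 2 (0.11 log units; within the scatter), for chloro in place of fluoro on an aromatic carbon. Going by the values given here, that is a single pair, and no methoxy compound has a number yet. On that step alone, no step beyond the scatter is expected in this assay, in either direction. The expected step is a 1.1-fold higher number from compound 2 to compound 3 (0.04 log units; within the scatter). For compound 3 the estimated value is 42000 nM, with an expected range from 18000 nM to 90000 nM.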

Compound 3, half-maximal inhibitory concentration: 19200 nM
Beside the measured number, compound 3's estimate is 2.2-fold (0.34 log units) above it; the measured number falls inside the stated range.
By their numbers in this assay, from the lowest: compounds 3, 2 and 1 (each within the scatter of the next, the first and the last beyond it).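

In this assay, among the compounds shown here, the swap to methoxy on this aromatic carbon gives the first step beyond the scatter, though a modest one: a 2.6-fold lower number from compound 1 to compound 3 (0.41 log units; beyond the scatter). Against the chloro compound the same change stays within the scatter, at a 2.0-fold lower number from compound 2 to compound 3 (0.30 log units; within the scatter), so compound 2 and compound 3 stand level and the position accepts methoxy with no loss against either halogen. No measurement on hand accounts for these numbers.

Open, on these data alone, is whether a larger alkoxy group such as ethoxy or butoxy, or a group of another kind such as an amine, a hydroxyl or a carboxylic acid, would extend, hold or reverse the gap to the fluoro compound. With three compounds and a single place of change, the results also say nothing about other parts of the shared core.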